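Methyl on the fused ring and cytotoxicity in the series

This account rests on a few compounds, and the source may have more. Where it says the series, first, only, none or still open, it means among the compounds named here.

compound 1 `COCOc1ccccc1-c1cc2ccccc2c(=O)n1C` — > 100000 nM
compound 2 `COCOc1ccccc1-c1cc2cc(C)ccc2c(=O)n1C` — 99800 nM
compound 3 `C=COc1ccccc1-c1c(Br)c2ccccc2c(=O)n1Cc1ccc(OC)cc1` — > 100000 nM

In a functional assay on A549 cells (Homo sapiens) for cytotoxicity, read by sulforhodamine B assay (on this read-out lower numbers stand for stronger inhibition and higher numbers for weaker inhibition), compound 1 gives only a limit, > 100000 nM. Compound 2 gives 99800 nM in this assay. The change between them is methyl in place of hydrogen on an aromatic carbon and the step is a number no higher from compound 1 to compound 2 (the limit leaves the size open); its size is not readable because of the limit of > 100000 nM in this assay, at which 2 of the 3 values shown sit. Compound 3 gives only a limit in this assay, > 100000 nM. How the core of compound 3 differs from the core of compound 1 is not broken down here.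

Compound 4 `C=COc1ccccc1-c1c(Br)c2cc(C)ccc2c(=O)n1Cc1ccc(OC)cc1` is not yet measured in this assay. Within the data shown here, it differs from compound 3 by methyl in place of hydrogen on an aromatic carbon, which is the same change as the one from compound 1 to compound 2, at the same place on the ring. Since that earlier step left compound 2 close to the limit where compound 1 sits, compound 4 is expected to stay near the limit of compound 3 in this assay, with an expected step of a number no higher from compound 3 to compound 4 (the limit leaves the size open). The estimate for compound 4 in this assay is 100000 nM, between 50000 nM and 300000 nM.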

Compound 4, half-maximal inhibitory concentration: 67800 nM
Compound 4: the middle estimate sits 1.5-fold (0.17 log units) above what was measured; low and high end bracket the measured number.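

In this assay, methyl in place of hydrogen on an aromatic carbon gives an at least 1.4-fold lower number from compound 3 to compound 4 (0.16 log units; that floor lies within the scatter), so the number does not rise with this change on the core of compound 3, and the same holds on the core of compound 1. Set side by side, the two steps agree in direction only as far as their limits allow: the same change on two cores in this assay, a number no higher (the limit leaves the size open) from compound 1 to compound 2 and an at least 1.4-fold lower number (0.16 log units; that floor lies within the scatter) from compound 3 to compound 4; the limit leaves it open whether they differ. This does not show that the change carries over with the same size, or that it gives a real gain on either core, and the step on the core of compound 1 cannot be read: the limit of > 100000 nM in this assay, at which 2 of the 4 values shown sit.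

Left open is whether a group other than methyl at this place on the ring, such as a longer chain, an amine or a carboxylic acid, would bring the number clearly below the limit on either core. Also open, from the compounds shown here alone, is how the methyl change behaves on a core whose parent compound has a measured number rather than a limit.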